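Diaryl urea series: chlorophenyl position on two amine chains

The source may report more compounds than this note shows. Statements on the series, on what has been measured and on what is new or still open speak of the compounds shown alone.

Compound 1 `CN(C)CCNc1nc(-c2ccc(NC(=O)Nc3ccc(Cl)cc3)cc2)nc2c(Cl)c(Cl)sc12` is the starting point. In a functional assay on MKN-45 cells (Homo sapiens) for cytotoxicity, read by MTT assay, with a stated time of 72 h (on this read-out lower numbers stand for stronger inhibition and higher numbers for weaker inhibition), compound 1 gives 910 nM. Compound 2 `CN(C)CCNc1nc(-c2ccc(NC(=O)Nc3ccccc3Cl)cc2)nc2c(Cl)c(Cl)sc12` differs from compound 1 by 2-chlorophenyl in place of 4-chlorophenyl on an amide-type nitrogen; in this assay compound 2 gives 1170 nM, and the step is a 1.3-fold higher number from compound 1 to compound 2 (0.11 log units; within the scatter). Compound 3 `CCN(CC)CCCNc1nc(-c2ccc(NC(=O)Nc3ccc(Cl)cc3)cc2)nc2c(Cl)c(Cl)sc12` carries a core that differs from that of compound 1 by (diethylamino)methyl in place of dimethylamino on a saturated chain carbon, two bonds along the chain from a nitrogen on an aromatic ring; in this assay compound 3 gives 720 nM, the step being a 1.3-fold lower number from compound 1 to compound 3 (0.10 log units; within the scatter). Compound 4 `CCN(CC)CCCNc1nc(-c2ccc(NC(=O)Nc3ccccc3Cl)cc2)nc2c(Cl)c(Cl)sc12` has not yet been measured and differs from compound 3 by 2-chlorophenyl in place of 4-chlorophenyl on an amide-type nitrogen. For the measured compounds named here, this is the same change as the one from compound 1 to compound 2, now made on the core of compound 3, and the place, an amide-type nitrogen whose other neighbour is a carbonyl carbon, reads the same in both cases. Going by the values given here, the only measured instance of this change is the pair of compound 1 and compound 2, so the expected step for compound 4 is a 1.3-fold higher number from compound 3 to compound 4 (0.11 log units; within the scatter), which rests on compound 1 because a 1.3-fold higher number from compound 1 to compound 2 (0.11 log units; within the scatter) is what the same change produced there. The estimate for compound 4 in this assay is 930 nM, expected to fall between 500 nM and 1800 nM.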

Compound 4, half-maximal inhibitory concentration: 1450 nM
Compound 4: middle estimate off by 1.6-fold (0.19 log units), on the low side; low and high end bracket the measured number.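

In this assay, 2-chlorophenyl in place of 4-chlorophenyl gives a 2.0-fold higher number from compound 3 to compound 4 (0.30 log units; within the scatter), and this agrees with the step seen for the same change on the core of compound 1: the same change on two cores in this assay, a 1.3-fold higher number (0.11 log units; within the scatter) from compound 1 to compound 2 and a 2.0-fold higher number (0.30 log units; within the scatter) from compound 3 to compound 4, 1.6-fold (0.19 log units) apart, within the scatter of two such steps

(Diethylamino)methyl in place of dimethylamino, with 2-chlorophenyl on the amide-type nitrogen, gives a 1.2-fold higher number from compound 2 to compound 4 (0.09 log units; within the scatter), and this also agrees with the earlier step for that change: the same change on two cores in this assay, a 1.3-fold lower number (0.10 log units; within the scatter) from compound 1 to compound 3 and a 1.2-fold higher number (0.09 log units; within the scatter) from compound 2 to compound 4, 1.6-fold (0.19 log units) apart, within the scatter of two such steps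

Across these four compounds, each change therefore reads alike on both cores, but all the steps lie within the scatter, so the agreement shows no measurable effect of either change and does not establish that a larger effect would carry from one core to the other.

Open, on these data alone, is whether a methoxyphenyl or fluorophenyl group on the same amide-type nitrogen would give a step beyond the scatter. Also open, as far as these compounds go, is whether a morpholine or piperidine in place of the dimethylamino group would do so, and whether such a step would hold on both cores.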